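Replacing a dimethylphenyl group with a thiazole

This account rests on a few compounds, and the source may have more. Where it says the series, first, only, none or still open, it means among the compounds named here.

Three measured compounds share one core and differ in a single aromatic group. In a functional assay on A549 cells (Homo sapiens) for cytotoxicity (a higher number here means that more compound is needed for the effect, a lower number that less compound is needed), compound 1 `COC1=C(C)C(=O)/C(=C(O)/C=C/c2cccc(OC)c2)C(=O)C1(C)C` gives 2.8 ug/mL, compound 2 `CCc1ccc(/C=C/C(O)=C2/C(=O)C(C)=C(OC)C(C)(C)C2=O)cc1` gives 6.1 ug/mL, and compound 3 `COC1=C(C)C(=O)/C(=C(O)/C=C/c2c(C)cccc2C)C(=O)C1(C)C` gives 8.3 ug/mL. Compound 3 therefore sits close to compound 2, with a gap of a 1.4-fold higher number from compound 2 to compound 3 (0.13 log units; within the scatter). Its distance from compound 1 is clearer: a 3.0-fold higher number from compound 1 to compound 3 (0.47 log units; beyond the scatter).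

The next compound, compound 4 `COC1=C(C)C(=O)/C(=C(O)/C=C/c2nccs2)C(=O)C1(C)C`, carries 1,3-thiazol-2-yl in place of 2,6-dimethylphenyl on a double-bonded chain carbon bound to a double-bonded chain carbon. Within the data shown here, no measured compound has a five-membered aromatic ring here, so the evidence is indirect. The only guides are the earlier swaps at this same place, namely a 2.2-fold higher number from compound 1 to compound 2 (0.34 log units; beyond the scatter) and the step to compound 3 given above. Both were modest, so a large jump in this assay seems unlikely, although the new ring leaves real uncertainty. The expected step is a 1.4-fold lower number from compound 3 to compound 4 (0.14 log units; within the scatter), which would not clearly separate the two compounds. For compound 4 the estimated value is 6 ug/mL, with an expected range from 2.5 ug/mL to 14 ug/mL.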

Compound 4, concentration for half-maximal effect: 3.5 ug/mL
Compound 4: middle estimate off by 1.7-fold (0.23 log units), on the high side, within the range that was stated.
By their numbers in this assay, from the lowest: compounds 1, 4, 2 and 3 (each within the scatter of the next, the first and the last beyond it).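

In this assay, this position turns out to tolerate more than a substituted six-membered aromatic ring of carbon only: putting 1,3-thiazol-2-yl in place of 2,6-dimethylphenyl gives a 2.4-fold lower number from compound 3 to compound 4 (0.38 log units; beyond the scatter) and so means less compound is needed, even though the entering group has 5 heavy atoms against 8 and brings hetero atoms to a place that so far held only substituted benzene rings. Set against the other two groups, the thiazole cannot be separated from either, since a 1.7-fold lower number from compound 2 to compound 4 (0.24 log units; within the scatter) and a 1.3-fold higher number from compound 1 to compound 4 (0.10 log units; within the scatter) both lie within the scatter, so the hetero atoms give no clear advantage over 4-ethylphenyl or 3-methoxyphenyl. No measurement available here explains any of these steps.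

The change from compound 3 to compound 4 swaps the ring size, the atoms in the ring and the two methyl groups all at once, so the data cannot say which of these matters. An unsubstituted phenyl ring, a thiophene with sulfur but no nitrogen, or an oxazole with oxygen in place of sulfur would each pull these apart, and an amine on the ring remains an open question at this position.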